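A few compounds are considered here, and "the series" means these few. Any claim that something is new, unique, unknown or untested is made for them only; others in the source may bear on it.

Compound 1 `O=C(/C=C/c1ccccc1)c1ccc(N2CCN(c3ccccc3F)CC2)cc1` and compound 2 `O=C(/C=C/c1ccccc1)c1ccc(N2CCN(c3cccc(Cl)c3Cl)CC2)cc1` share one core and differ only in the aryl group on the piperazine-type ring nitrogen. In a functional assay on the whole organism (strain Kunming) for inhibition, with Mus musculus as the target, with a stated time of 1 h, at a dose of 40 mg/kg by the oral route (on this read-out lower numbers stand for less inhibition and higher numbers for more inhibition at the one dose given (going by the name of the read-out)), compound 1 gives 0.57%, the lowest of the two numbers, while compound 2 gives 30.7%. Going by the values given here, the only measured step, a number 30.1 percentage points higher from compound 1 to compound 2 (beyond the scatter), shows that exchanging this aryl group can move the read-out well beyond the scatter. Compound 3 `COc1cccc(N2CCN(c3ccc(C(=O)/C=C/c4ccccc4)cc3)CC2)c1` is not yet measured. Its difference from compound 1 is 3-methoxyphenyl in place of 2-fluorophenyl on an amine nitrogen in a ring. Among the compounds with values here, no measured pair exchanges a 2-fluorophenyl for a 3-methoxyphenyl, so the step from compound 1 to compound 2 bears on it only by showing that a change at this position may be large, without fixing the direction. Because of a number 30.1 percentage points higher from compound 1 to compound 2 (beyond the scatter) an increase is expected for compound 3 rather than none, and the step is estimated as a number 14.4 percentage points higher from compound 1 to compound 3 (beyond the scatter). Compound 3 is therefore expected to give about 15%, between 0% and 40%.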

Compound 3, a percentage reported as inhibition, in the whole organism at one dose (the size of the read-out at that dose, not a potency): 16%
Estimate against measurement, compound 3: 1 percentage points below; the measured number falls inside the stated range.
By their numbers in this assay, from the lowest: compound 1; then compound 3; then compound 2.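

In this assay, the 3-methoxyphenyl group gives a third level at this place on the amine nitrogen in the ring, with a number 15.4 percentage points higher from compound 1 to compound 3 (beyond the scatter) and with a number 14.7 percentage points lower from compound 2 to compound 3 (beyond the scatter). Going by these compounds alone, the earlier pair showed only that two aryl groups could lie far apart, whereas these three compounds now form a graded series of clearly separate levels, not just a high and a low. No available evidence accounts for this order of the three aryl groups.

The 2-fluorophenyl and 3-methoxyphenyl groups differ in both the substituent and its numbered ring position, and this step does not separate those two changes. The compounds shown also leave open how a benzyl group or a simple alkyl chain on the same nitrogen would read out.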